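Serum half-life across carbonyl-carbon substituents on the shared core

This account rests on a few compounds, and the source may have more. Where it says the series, first, only, none or still open, it means among the compounds named here.

Measured so far in an ADME assay on the whole organism (serum) with Homo sapiens as the target; a higher number here means that the compound lasts longer, a lower number that the compound disappears faster:
compound 1 `Cc1cn(C2CC(N=[N+]=[N-])C(COC(=O)CCCC(=O)OC(C)(C)C)O2)c(=O)[nH]c1=O` gives 0.55 h
compound 2 `Cc1cn(C2CC(N=[N+]=[N-])C(COC(=O)OCCO)O2)c(=O)[nH]c1=O` gives < 0.0167 h, which is a limit of this assay
compound 3 `Cc1cn(C2CC(N=[N+]=[N-])C(COC(=O)OCCCO)O2)c(=O)[nH]c1=O` gives 0.167 h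

Compound 1 stands highest of the two numbers; its nearest neighbour is compound 3, with a 3.3-fold lower number from compound 1 to compound 3 (0.52 log units; beyond the scatter). For compound 2 only a limit is known, (the limit of < 0.0167 h in this assay, at which 1 of the 3 values shown sits). Compound 4 `Cc1cn(C2CC(N=[N+]=[N-])C(COC(=O)OCCCC(=O)O)O2)c(=O)[nH]c1=O` differs from compound 1 by 3-carboxypropoxy in place of 3-(tert-butoxycarbonyl)propyl on a carbonyl carbon. Within the data shown here, the steps that bear on this both replace the same group on the carbonyl carbon with a chain carrying a hydrogen-bond donor: a 3.3-fold lower number from compound 1 to compound 3 (0.52 log units; beyond the scatter) and an at least 32-fold lower number from compound 1 to compound 2 (1.51 log units; beyond the scatter). Both lowered the number beyond the scatter, so a lower number is expected for compound 4, modest to large. Compound 4 is estimated at 0.15 h (range 0.04 h to 0.5 h), a step of a 3.7-fold lower number from compound 1 to compound 4 (0.56 log units; beyond the scatter).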

Compound 4, half-life: 13 h
The estimate for compound 4 lay 87-fold (1.94 log units) below the measured number; measured number outside the range, above it.
By their numbers in this assay, from the lowest: compound 3; then compound 1; then compound 4. At a limit, below all of these: compound 2.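

In this assay, a chain carrying a hydrogen-bond donor on this carbonyl carbon need not lower the number: 3-carboxypropoxy gives a 24-fold higher number from compound 1 to compound 4 (1.37 log units; beyond the scatter), against the lower numbers of the two hydroxy chains. The chain end carries the change, with carboxy in place of hydroxy giving a 78-fold higher number from compound 3 to compound 4 (1.89 log units; beyond the scatter) and carboxymethyl in place of hydroxy giving an at least 770-fold higher number from compound 2 to compound 4 (2.89 log units; beyond the scatter). Compound 2 is a limit, so that last step is only a bound: the limit of < 0.0167 h in this assay, at which 1 of the 4 values shown sits.

On these data alone, a methyl ester or an amine at the chain end remains open. So does a longer chain ending in carboxy.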